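Allyl for methyl on the aromatic nitrogen: compound 4

This account rests on a few compounds, and the source may have more. Where it says the series, first, only, none or still open, it means among the compounds named here.

Measured so far, in an assay on lung parenchyma for binding affinity to cysteinyl leukotriene receptor 1 (Cavia porcellus), read by radioligand binding; a lower number here means a stronger inhibitor, a higher number a weaker inhibitor:
compound 1 `COc1cc(C(=O)NS(=O)(=O)c2ccccc2C)ccc1Cc1cn(C)c2ccc(C(=O)NCC3CCCC3)cc12`, 3.16 nM
compound 2 `CCC(C)CNC(=O)c1ccc2c(c1)c(Cc1ccc(C(=O)NS(=O)(=O)c3ccccc3C)cc1OC)cn2C`, 5.01 nM
compound 3 `CCC(CC)CNC(=O)c1ccc2c(c1)c(Cc1ccc(C(=O)NS(=O)(=O)c3ccccc3C)cc1OC)cn2C(C)C`, 0.501 nM

Compound 1 stands second highest of the three numbers: the step of a 1.6-fold higher number from compound 1 to compound 2 (0.20 log units; within the scatter) is within the scatter, while compound 3 sits well lower, beyond it. Compound 4 `C=CCn1cc(Cc2ccc(C(=O)NS(=O)(=O)c3ccccc3C)cc2OC)c2cc(C(=O)NCC3CCCC3)ccc21` differs from compound 1 by vinyl in place of hydrogen on a saturated chain carbon bound to an aromatic nitrogen. Going by the values given here, no measured step changes only this place. Among the compounds with values here, the one measured step, a 1.6-fold higher number from compound 1 to compound 2 (0.20 log units; within the scatter), concerns the amide side chain and is within the scatter. Compound 3 carries a larger group on the same aromatic nitrogen but also a different amide chain, so its lower value cannot be attributed to either change alone. For compound 4 a modest move toward a lower number is expected, a 2.0-fold lower number from compound 1 to compound 4 (0.30 log units; within the scatter), with 1.6 nM estimated, between 0.4 nM and 6 nM.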

Compound 4, inhibition constant: 0.398 nM
Compound 4: middle estimate off by 4.0-fold (0.60 log units), on the high side, and the stated range ends above it.
By their numbers in this assay, from the lowest: compounds 4 and 3 (each within the scatter of the next); then compounds 1 and 2 (each within the scatter of the next).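

In this assay, the aromatic nitrogen is a place where the number responds on its own: with the amide chain held constant, allyl for methyl gives a step beyond the scatter (a 7.9-fold lower number from compound 1 to compound 4 (0.90 log units; beyond the scatter)). Going by these compounds alone, the only earlier step (a 1.6-fold higher number from compound 1 to compound 2 (0.20 log units; within the scatter)) changed the amide chain and stayed within the scatter, and compound 3 changed both places at once. Nothing measured here accounts for the size of this step.

Whether the double bond matters or only the added carbons would take propyl on the same nitrogen to settle. As far as these compounds go, how a benzyl group or a longer chain ending in a carboxylic acid would read there also remains open.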